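A few compounds are considered here, and "the series" means these few. Any claim that something is new, unique, unknown or untested is made for them only; others in the source may bear on it.

Measured in an ADME assay (liver) for metabolic stability, with Liver microsome (Homo sapiens) as the target, using microsomes, tested at 1 uM; on this read-out lower numbers stand for slow clearance and higher numbers for fast clearance:
- compound 1 `CCC1=C(c2cc(OC)c(OC)c(OC)c2)c2ccc(OC)c(O)c2CCC1`: 136 mL.min-1.g-1
- compound 2 `COc1ccc2c(c1O)CCCC(C)=C2c1cc(OC)c(OC)c(OC)c1`: 108 mL.min-1.g-1
- compound 3 `COc1ccc2c(c1O)CCCC(CC(O)CO)=C2c1cc(OC)c(OC)c(OC)c1`: 66.3 mL.min-1.g-1

Compound 3 stands within the scatter of compound 2, with a 1.6-fold lower number from compound 2 to compound 3 (0.21 log units; within the scatter). Its number lies clearly under that of compound 1, with a 2.1-fold lower number from compound 1 to compound 3 (0.31 log units; beyond the scatter). Compound 4 `COc1ccc2c(c1O)CCCC(Cc1ccccc1)=C2c1cc(OC)c(OC)c(OC)c1` has not yet been measured. It differs from compound 3 as follows: phenyl in place of 1,2-dihydroxyethyl on a saturated chain carbon bound to a double-bonded ring carbon. In words, phenyl takes the place of 1,2-dihydroxyethyl.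

The two steps that introduce 1,2-dihydroxyethyl are the ones that bear on this change, and both are small. Compounds 1 and 2, which lack that group, agree with each other, with a 1.3-fold lower number from compound 1 to compound 2 (0.10 log units; within the scatter). Among the measured compounds shown here, no measured compound carries phenyl at this place, so the data offer no direct step for it. The expectation is therefore that compound 4 returns to about the level of compound 1, at 136 mL.min-1.g-1, in this assay. The expected change is a 2.1-fold higher number from compound 3 to compound 4 (0.32 log units; beyond the scatter). For compound 4 the estimated value is 140 mL.min-1.g-1, with an expected range of 75 mL.min-1.g-1 to 260 mL.min-1.g-1.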

Compound 4, intrinsic clearance in microsomes: 51.2 mL.min-1.g-1
Beside the measured number, compound 4's estimate is 2.7-fold (0.44 log units) above it; the whole stated range lies above it.
By their numbers in this assay, from the lowest: compounds 4, 3, 2 and 1 (each within the scatter of the next, the first and the last beyond it).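

In this assay phenyl at this place, on a saturated chain carbon bound to a double-bonded ring carbon, gives a step beyond the scatter both in place of hydrogen (a 2.1-fold lower number from compound 2 to compound 4 (0.32 log units; beyond the scatter)) and in place of methyl (a 2.7-fold lower number from compound 1 to compound 4 (0.42 log units; beyond the scatter)). Phenyl in place of 1,2-dihydroxyethyl stays within the scatter (a 1.3-fold lower number from compound 3 to compound 4 (0.11 log units; within the scatter)), so among these compounds a lower number does not require hydroxyl groups at this place. Nothing measured here explains why these two different groups give readings that cannot be told apart.

Going by these compounds, it remains open whether an amine or a carboxylic acid on this chain would read with compound 3 and compound 4 or with compound 1. A longer alkyl chain, or a phenyl ring carrying fluorine, is equally undecided.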